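Ester swap on a shared core: cyclohexyl to cyclobutylmethyl

A few compounds are considered here, and "the series" means these few. Any claim that something is new, unique, unknown or untested is made for them only; others in the source may bear on it.

Measured so far:
compound 1 `CCCOC(=O)C1=C(C)NC(=O)NC1c1ccoc1` 50%
compound 2 `CC1=C(C(=O)OCC2CCC2)C(c2ccco2)NC(=O)N1` 42%
compound 3 `CC1=C(C(=O)OC2CCCCC2)C(c2ccoc2)NC(=O)N1` 15%

All three compounds share one core and differ in the group on the ester oxygen, and in one case elsewhere. In an assay on membranes from CHO cells for displacement of a labelled ligand from adenosine receptor A1 (Homo sapiens), read by scintillation counting, with a stated time of 60 min, tested at 1 uM (a lower number here means less inhibition, a higher number more inhibition at the concentration tested (going by the name of the read-out)), compound 3 gives 15%, the lowest of the three numbers; compound 2, with 42%, and compound 1, with 50%, both sit clearly above it. Compound 4 `CC1=C(C(=O)OCC2CCC2)C(c2ccoc2)NC(=O)N1` has not yet been measured. It differs from compound 3 in one place: cyclobutylmethyl in place of cyclohexyl on an oxygen next to a carbonyl group.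

Among the measured compounds shown here, one measured step bears on this. Going a number 35 percentage points lower from compound 1 to compound 3 (beyond the scatter) shows that replacing propyl with cyclohexyl on the oxygen next to a carbonyl group cost a great deal. Compound 2 carries the same cyclobutylmethyl ester but differs from compound 4 elsewhere, so its value is only a loose hint; still, with that ester compound 2 shows 42%. Leaving cyclohexyl for cyclobutylmethyl is therefore expected to recover part of what was lost, giving an upward step of about a number 20 percentage points higher from compound 3 to compound 4 (beyond the scatter). Compound 4 is thus estimated at 35%, with a likely range from 15% to 55%.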

Compound 4, a percentage reported as inhibition, at one concentration (the size of the read-out at that concentration, not a potency): 46%
Compound 4: the middle estimate sits 11 percentage points below what was measured; low and high end bracket the measured number.
By their numbers in this assay, from the lowest: compound 3; then compounds 2, 4 and 1 (each within the scatter of the next).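

In this assay a ring carried on this oxygen is not in itself a penalty, since cyclobutylmethyl in place of cyclohexyl gives a number 31 percentage points higher from compound 3 to compound 4 (beyond the scatter) and so a large recovery from the low number of the cyclohexyl compound. The ring-bearing group also matches the open chain, as cyclobutyl in place of ethyl on the saturated chain carbon gives a number 4 percentage points lower from compound 1 to compound 4 (within the scatter) and leaves the cyclobutylmethyl and propyl groups indistinguishable here. With the cyclobutylmethyl group in place, furan-3-yl in place of furan-2-yl gives a number 4 percentage points higher from compound 2 to compound 4 (within the scatter) and so the two furans cannot be told apart in this pair, which shows that the value of compound 2, earlier only a loose hint, did reflect this group fairly.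

Nothing in the data explains why the cyclohexyl group stands so far below the others. Whether a cyclopentyl group, a longer chain such as butyl or a group carrying an amine on this oxygen would hold the number at this level stays open, and a reading at one concentration gives no potency for any of these compounds.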